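The source may hold more compounds than are shown below. What is called first, only, known or untested is meant among the compounds shown, and "the series" means these compounds.

Compound 2 `Nc1ccccc1NC(=O)c1ccc(Cn2cnc3c(Nc4ccccc4)nc(Cl)nc32)cc1` is, on the numbers shown, the one giving the highest read-out in a functional assay on HCT-116 cells (Homo sapiens) for antiproliferative activity, read by CCK-8 assay, with a stated time of 72 h, tested at 2 uM; a higher number here means a stronger effect of the compound at the concentration tested, a lower number a weaker effect: compound 2 gives 71.4%. Compound 3 `Nc1ccccc1NC(=O)c1ccc(Cn2cnc3c(Nc4ccc(-c5ccccn5)cc4)nc(Cl)nc32)cc1`, which carries pyridin-2-yl in place of hydrogen on an aromatic carbon, gives 69.5%, so that a number 1.9 percentage points lower from compound 2 to compound 3 (within the scatter). Compound 1 `CC1CCN(c2nc(Cl)nc3c2ncn3Cc2ccc(/C=C/C(=O)Nc3ccccc3N)cc2)CC1`, whose core bears 4-methylpiperidin-1-yl and whose linker is different, gives 4.24%, far below compound 2 in this assay.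

Compound 4 `CC1CCN(c2nc(Cl)nc3c2ncn3Cc2ccc(C(=O)Nc3ccccc3N)cc2)CC1` has not yet been measured. It differs from compound 2 in one place: 4-methylpiperidin-1-yl in place of anilino on an aromatic carbon, on an aromatic carbon next to the ring nitrogen, ortho to a fused ring and meta to a chloro group. Within the data shown here, no measured step follows this exact change, since compound 1 differs from compound 2 in the linker as well as in this group. Among the measured compounds shown here, the only measured step, between compound 2 and compound 3, changes a different part of the molecule and is within the scatter, so it does not bear on the expected size.

Given that compound 1, the only measured compound with 4-methylpiperidin-1-yl, gives 4.24%, compound 4 is expected to sit well below compound 2, with a number 43.4 percentage points lower from compound 2 to compound 4 (beyond the scatter), though the changed linker in compound 1 leaves this uncertain. The estimate for compound 4 in this assay is 28%, in the range 3% to 65%.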

Compound 4, a percentage reported as inhibition, at one concentration (the size of the read-out at that concentration, not a potency): 70.9%
Compound 4: the middle estimate sits 42.9 percentage points below what was measured, outside the stated range (above it).
By their numbers in this assay, from the lowest: compound 1; then compounds 3, 4 and 2 (each within the scatter of the next).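

In this assay, the aromatic carbon next to the ring nitrogen takes 4-methylpiperidin-1-yl in place of anilino with a number 0.5 percentage points lower from compound 2 to compound 4 (within the scatter), so neither the aromatic ring of anilino nor its hydrogen-bond donor is needed for this read-out at the concentration tested. Among these compounds, with 4-methylpiperidin-1-yl held constant, (2-aminophenyl)carbamoyl in place of 2-((2-aminophenyl)carbamoyl)ethenyl gives a number 66.7 percentage points higher from compound 1 to compound 4 (beyond the scatter), so the low read-out of compound 1 goes with that linker and not with the group on the core, which the earlier compounds could not separate. No supporting data bear on why either step turns out as it does.

As far as these compounds go, these read-outs are taken at one concentration, so compound 2 and compound 4 may still differ in the strength of their effect at other concentrations, and it remains open whether the linker step would be as large in a compound carrying anilino. From the compounds shown here alone, it is also open how far this tolerance extends at the same carbon, for instance to a morpholine ring or a small dimethylamino group, or whether the chloro group on the shared core could give way to an amine.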